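The compounds below may be only part of what the source reports. "The series", "measured", "known", "first", "only" and "open" are said of these compounds alone.

Working notes on the series. In a functional assay on DU-145 cells (Homo sapiens) for inhibition, read by trypan blue exclusion, with a stated time of 72 h (a lower number here means a stronger inhibitor, a higher number a weaker inhibitor), compound 1 (`Cn1c(=O)c(C(=O)Nc2ccc(F)cc2F)cc2cnc(Nc3ccc4[nH]ccc4c3)nc21`) gives 5000 nM and compound 2 (`Cn1c(=O)c(S(=O)(=O)c2ccc(Br)cc2)cc2cnc(Nc3ccc4[nH]ccc4c3)nc21`) gives 5000 nM so compound 2 sits level with compound 1. Among the measured compounds shown here, the only measured step, no change at the digits printed from compound 1 to compound 2 (within the scatter) on an aromatic carbon, stays within the scatter and offers the sole guide. Compound 3 (`Cn1c(=O)c(S(=O)(=O)c2ccc(F)cc2N)cc2cnc(Nc3ccc4[nH]ccc4c3)nc21`) carries 2-amino-4-fluorophenyl in place of 4-bromophenyl on a sulfonyl sulfur. For the measured compounds named here, no measured step covers a change at that place, so no shift beyond the scatter is expected in this assay and the expected step is small (a 1.3-fold lower number from compound 2 to compound 3 (0.10 log units; within the scatter)). For compound 3 the estimated value is 4000 nM with an expected range of 1200 nM to 12000 nM in this read-out.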

Compound 3, half-maximal inhibitory concentration: 3000 nM
Beside the measured number, compound 3's estimate is 1.3-fold (0.12 log units) above it, and the stated range covers the measured number.
By their numbers in this assay, from the lowest: compounds 3, 1 and 2 (each within the scatter of the next).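

On a sulfonyl sulfur, 2-amino-4-fluorophenyl replaces 4-bromophenyl in this assay with a 1.7-fold lower number from compound 2 to compound 3 (0.22 log units; within the scatter), so this first change at that place, which brings in a hydrogen-bond donor and acceptor, does not leave the scatter. Set against the (2,4-difluorophenyl)carbamoyl group, (2-amino-4-fluorophenyl)sulfonyl gives a 1.7-fold lower number from compound 1 to compound 3 (0.22 log units; within the scatter), so all three groups remain indistinguishable in this read-out. No supporting data bear on this result.

From the compounds shown here alone, whether any group at this place can move the number beyond the scatter remains open. A carboxylic acid or a morpholine on the phenyl ring would test this.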